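Aryl swap on the shared core: outlook for compound 4

The compounds below may be only part of what the source reports. "The series", "measured", "known", "first", "only" and "open" are said of these compounds alone.

Compound 1, `CC(C)C[C@H](N)CN(C(=O)[C@@H]1C[C@H]1c1ccccc1)c1ccc(-c2ccncc2)cc1`, in a functional assay for agonist activity at G protein-coupled receptor 88 (Homo sapiens), read by HTRF and cAMP accumulation (a higher number here means that more compound is needed for the effect, a lower number that less compound is needed), gives 13000 nM.
Compound 2, `CC(C)C[C@H](N)CN(C(=O)[C@@H]1C[C@H]1c1ccccc1)c1ccc(C2=CCCC2)cc1`, in this assay gives 1200 nM.
Compound 3, `Cc1cccc(-c2ccc(N(C[C@@H](N)CC(C)C)C(=O)[C@@H]3C[C@H]3c3ccccc3)cc2)c1`, in this assay gives 1200 nM.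

Compound 3 stands level with compound 2 at the digits shown, the two together the lowest of the three numbers; compound 1 lies furthest off, an 11-fold lower number from compound 1 to compound 3 (1.03 log units; beyond the scatter). Compound 4, `Cc1ccccc1-c1ccc(N(C[C@@H](N)CC(C)C)C(=O)[C@@H]2C[C@H]2c2ccccc2)cc1`, differs from compound 3 only in 2-methylphenyl in place of 3-methylphenyl on an aromatic carbon. Within the data shown here, no measured step moves the methyl within that ring. The steps touching this position are an 11-fold lower number from compound 1 to compound 2 (1.03 log units; beyond the scatter) and an 11-fold lower number from compound 1 to compound 3 (1.03 log units; beyond the scatter), both large, whereas no change at the digits printed from compound 2 to compound 3 (within the scatter). Those steps exchange whole groups; the step to compound 4 merely shifts a methyl, so no step beyond the scatter is expected in this assay, with some allowance toward a higher number. For compound 4 the estimate in this assay is 2000 nM, range 600 nM to 7000 nM. For compound 4 this means an expected 1.7-fold higher number from compound 3 to compound 4 (0.22 log units; within the scatter).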

Compound 4, half-maximal effective concentration: 3400 nM
For compound 4 the middle estimate is 1.7-fold (0.23 log units) below the measured one; the range from low to high includes it.
By their numbers in this assay, from the lowest: compounds 2 and 3 (each within the scatter of the next); then compound 4; then compound 1.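

In this assay, among these compounds, moving the methyl around the phenyl ring is not neutral, although the group keeps the same atoms: a 2.8-fold higher number from compound 3 to compound 4 (0.45 log units; beyond the scatter) is the first step beyond the scatter within the aryl groups carrying a methyl. The 2-methylphenyl group also trails cyclopent-1-en-1-yl, with a 2.8-fold higher number from compound 2 to compound 4 (0.45 log units; beyond the scatter) as the step, yet a 3.8-fold lower number from compound 1 to compound 4 (0.58 log units; beyond the scatter) shows that it retains part of the advantage over pyridin-4-yl. Nothing available explains this shift.

Still open, on these data alone, is how 4-methylphenyl would compare with these two isomers. Equally open, as far as these compounds go, is whether a chlorine atom or a methoxy group would behave like the methyl in the 2-methylphenyl group.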